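Aryl exchange from compound 1 to compound 4

The source may hold more compounds than are shown below. What is called first, only, known or untested is meant among the compounds shown, and "the series" means these compounds.

In a functional assay on SW480 cells (Homo sapiens) for antiproliferative activity, read by sulforhodamine B assay, with a stated time of 48 h (a higher number here means a weaker inhibitor, a lower number a stronger inhibitor), compound 1 (`COc1cc(C=C(C(=O)/C=C/c2cccc(OC)c2OC)C(=O)/C=C/c2cccc(OC)c2OC)ccc1O`) gives 430 nM and holds the second highest of three numbers. Compound 2 (`COc1ccc(C=C(C(=O)/C=C/c2cccc(OC)c2OC)C(=O)/C=C/c2cccc(OC)c2OC)cc1OC`) gives 410 nM and compound 3 (`COc1cc(OC)c(C=C(C(=O)/C=C/c2cccc(OC)c2OC)C(=O)/C=C/c2cccc(OC)c2OC)c(OC)c1`) gives 840 nM on the same read-out. Compound 4 (`COc1cccc(C=C(C(=O)/C=C/c2cccc(OC)c2OC)C(=O)/C=C/c2cccc(OC)c2OC)c1OC`) has 2,3-dimethoxyphenyl in place of 4-hydroxy-3-methoxyphenyl (2,3-dimethoxyphenyl in place of 4-hydroxy-3-methoxyphenyl on a double-bonded chain carbon bound to a double-bonded chain carbon) on a double-bonded chain carbon bound to a double-bonded chain carbon. For the measured compounds named here, three measured steps bear on this change. Methyl in place of hydrogen on an oxygen gave almost nothing (a 1.0-fold lower number from compound 1 to compound 2 (0.02 log units; within the scatter)). Exchange for 2,4,6-trimethoxyphenyl gave small steps (a 2.0-fold higher number from compound 1 to compound 3 (0.29 log units; within the scatter); a 2.0-fold higher number from compound 2 to compound 3 (0.31 log units; beyond the scatter)). No step beyond the scatter is therefore expected in this assay. The expected step is small (a 1.2-fold higher number from compound 1 to compound 4 (0.07 log units; within the scatter)). Compound 4 is estimated at 500 nM (range 250 nM to 1000 nM).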

Compound 4, half-maximal inhibitory concentration: 590 nM
Estimate against measurement, compound 4: 1.2-fold (0.07 log units) below; the measured number falls inside the stated range.
By their numbers in this assay, from the lowest: compounds 2, 1, 4 and 3 (each within the scatter of the next, the first and the last beyond it).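

In this assay, 2,3-dimethoxyphenyl at this place on the double-bonded chain carbon gives only steps within the scatter (a 1.4-fold higher number from compound 1 to compound 4 (0.14 log units; within the scatter); a 1.4-fold higher number from compound 2 to compound 4 (0.16 log units; within the scatter); a 1.4-fold lower number from compound 3 to compound 4 (0.15 log units; within the scatter)). The entering group has 0 hydrogen-bond donors and the leaving group 1, yet the step from 4-hydroxy-3-methoxyphenyl stays within the scatter. Compound 4, like compound 1, lies within the scatter of both compound 2 and compound 3.

Open is whether an aryl group carrying an amine or a carboxylic acid at this place would stay within the scatter of these compounds. No measured evidence accounts for these steps.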